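This account rests on a few compounds, and the source may have more. Where it says the series, first, only, none or still open, it means among the compounds named here.

Compound 1 `O=C(COc1ccc(CNC2CC=C(c3c[nH]c4cccc(F)c34)CC2)c(F)c1)NO`: 173 nM
Compound 2 `Cc1ccc2[nH]cc(C3=CCC(NCc4ccc(OCC(=O)NO)cc4F)CC3)c2c1`: 445 nM
Compound 3 `O=C(COc1ccc(CNC2CC=C(c3c[nH]c4ccccc34)CC2)c(F)c1)NO`: 436 nM

These values come from a functional assay on HCT-116 cells (Homo sapiens) for antiproliferative activity, with a stated time of 72 h; on this read-out lower numbers stand for stronger inhibition and higher numbers for weaker inhibition. Compound 1 gives the lowest number of the three and is the most potent here, with the other two each beyond the scatter from it. Compound 4 `Cc1[nH]c2cccc(F)c2c1C1=CCC(NCc2ccc(OCC(=O)NO)cc2F)CC1` keeps the core of compound 1 and differs in one place: methyl in place of hydrogen on an aromatic carbon. This is methyl in place of hydrogen on an aromatic carbon, next to the ring nitrogen and next to the ring atom that bears a large group.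

For the measured compounds named here, no measured step touches that carbon, so the evidence is indirect. Two steps alter the 4-fluoro-1H-indol-3-yl group elsewhere, and both are modest: a 2.5-fold higher number from compound 1 to compound 3 (0.40 log units; beyond the scatter) and a 2.6-fold higher number from compound 1 to compound 2 (0.41 log units; beyond the scatter). A methyl on a different carbon shows no effect beyond the scatter in a 1.0-fold lower number from compound 2 to compound 3 (0.01 log units; within the scatter). Neither change to compound 1 at 173 nM gave a lower number, so a modest step towards a higher number is expected, though no step beyond the scatter remains possible. The expected change is estimated as a 1.5-fold higher number from compound 1 to compound 4 (0.18 log units; within the scatter). Compound 4 is expected at 260 nM, with an estimated range from 90 nM to 750 nM.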

Compound 4, half-maximal inhibitory concentration: 254 nM
For compound 4 the middle estimate is 1.0-fold (0.01 log units) above the measured one; the range from low to high includes it.
By their numbers in this assay, from the lowest: compounds 1, 4, 3 and 2 (each within the scatter of the next, the first and the last beyond it).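

In this assay, for the compounds shown here, compound 4 gives the first reading at this aromatic carbon, next to the ring nitrogen and next to the ring atom that bears a large group, and the step for methyl in place of hydrogen is a 1.5-fold higher number from compound 1 to compound 4 (0.17 log units; within the scatter). The earlier compounds shown here showed a methyl only on a different carbon, so this result adds that the position can carry a methyl with no shift beyond the scatter, leaving compound 4 and compound 1 indistinguishable on this read-out. Taken with the earlier methyl step, the two cases agree, although this covers only these compounds: the same change on two cores in this assay, a 1.0-fold lower number (0.01 log units; within the scatter) from compound 2 to compound 3 and a 1.5-fold lower number (0.17 log units; within the scatter) from compound 4 to compound 1, 1.4-fold (0.16 log units) apart, within the scatter of two such steps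

The compounds shown leave open whether this carbon would tolerate a group other than methyl, such as an ethyl, a trifluoromethyl, an amine or a carboxylic acid, where a step beyond the scatter might still appear. They also leave open whether a methyl at this same carbon would give a similar result on the core of compound 3, which has hydrogen in place of fluoro.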